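Chain Extension on the Alkyne of Two Pyrimidinedione Cores

The source may hold more compounds than are shown below. What is called first, only, known or untested is meant among the compounds shown, and "the series" means these compounds.

The study looks at four compounds built around two related cores. Compound 1 `CCCCCC#Cc1cn(CCC(COC(C)=O)COC(C)=O)c(=O)n(C(=O)c2ccccc2)c1=O` carries a short chain on the triple bond, and in a functional assay on HeLa cells (Homo sapiens) for antiproliferative activity, read by MTT assay, with a stated time of 72 h (on this read-out lower numbers stand for stronger inhibition and higher numbers for weaker inhibition), compound 1 gives 53700 nM. Compound 2 `CCCCCCCCC#Cc1cn(CCC(COC(C)=O)COC(C)=O)c(=O)n(C(=O)c2ccccc2)c1=O` differs from it by propyl in place of hydrogen on a saturated chain carbon, five bonds along the chain from a triple-bonded carbon, and in this assay compound 2 gives 32400 nM, a step of a 1.7-fold lower number from compound 1 to compound 2 (0.22 log units; within the scatter). Compound 3 `CCCCCC#Cc1cn(CCC(CO)CO)c(=O)[nH]c1=O` has a different core; how its core differs from that of compound 1 is not broken down here. In this assay compound 3 gives 76300 nM. Compound 4 `CCCCCCCCC#Cc1cn(CCC(CO)CO)c(=O)[nH]c1=O`, not yet measured, differs from compound 3 by the same change, (propyl in place of hydrogen on a saturated chain carbon, five bonds along the chain from a triple-bonded carbon). For compound 4 the step of a 1.6-fold lower number from compound 3 to compound 4 (0.20 log units; within the scatter) in this assay is expected, resting on the earlier step of a 1.7-fold lower number from compound 1 to compound 2 (0.22 log units; within the scatter) from the first pair. Compound 4 is estimated at 48000 nM, between 22000 nM and 105000 nM.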

Compound 4, half-maximal inhibitory concentration: 58900 nM
Beside the measured number, compound 4's estimate is 1.2-fold (0.09 log units) below it; low and high end bracket the measured number.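

In this assay, propyl in place of hydrogen on a saturated chain carbon, five bonds along the chain from a triple-bonded carbon, gives a 1.3-fold lower number from compound 3 to compound 4 (0.11 log units; within the scatter). Set beside the first pair, the change carries from one core to the other with no measurable difference in the size of its step: the same change on two cores in this assay, a 1.7-fold lower number (0.22 log units; within the scatter) from compound 1 to compound 2 and a 1.3-fold lower number (0.11 log units; within the scatter) from compound 3 to compound 4, 1.3-fold (0.11 log units) apart, within the scatter of two such steps. Both steps lie within the scatter, however: the two pairs show agreement between small steps, not a real gain from the added propyl, and they set no rule for other cores.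

The compounds shown leave open how a still longer chain on the triple bond would read in this assay. Also open, going by these compounds, is how a chain ending in an amine or a carboxylic acid would read there.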